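A few compounds are considered here, and "the series" means these few. Any claim that something is new, unique, unknown or untested is made for them only; others in the source may bear on it.

Measured in a functional assay on HCT-116 cells (Homo sapiens) for cytotoxicity, read by MTT assay, with a stated time of 72 h; a higher number here means a weaker inhibitor, a lower number a stronger inhibitor:
compound 1 `Nc1cccc(Nc2c(C(=O)NCc3ccc(F)cc3)nc(Br)c3cccnc23)c1`: > 10000 nM (a limit)
compound 2 `C[C@@H](Nc1c(C(=O)NCc2ccc(F)cc2)nc(Br)c2cccnc12)c1ccccc1`: > 20000 nM (a limit)
compound 3 `N[C@H]1CC[C@H](Nc2c(C(=O)NCc3ccc(F)cc3)nc(Br)c3cccnc23)CC1`: 4000 nM

Going by the values given here, compound 3 holds the only true number in the set, and it is the lowest reading of the three. The values of the other two compounds are limits, not numbers. Two measured steps lead to compound 3 through a change on the same nitrogen: an at least 2.5-fold lower number from compound 1 to compound 3 (0.39 log units; beyond the scatter), and an at least 5.0-fold lower number from compound 2 to compound 3 (0.69 log units; beyond the scatter). Both are open-ended, so they give only a minimum size.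

Compound 4 `CNc1c(C(=O)NCc2ccc(F)cc2)nc(Br)c2cccnc12` has not been measured. It carries methyl in place of 4-aminocyclohexyl on a nitrogen on an aromatic ring. Among the compounds with values here, no measured compound carries methyl at this place, so the support is indirect. Still, neither compound 1 nor compound 2 reached a number once 4-aminocyclohexyl was absent, and a modest step towards weaker inhibition is expected in this assay. A reading reported only as a limit would fit this expectation equally well.

The expected change is a 3.0-fold higher number from compound 3 to compound 4 (0.48 log units; beyond the scatter). Compound 4 is estimated at 12000 nM, with an expected range from 4000 nM to 40000 nM.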

Compound 4, half-maximal inhibitory concentration: > 20000 nM
Compound 4 gave a limit, no number; the forecaster's own chance of this, stated with the estimate: 50%; middle value at least 1.6-fold (0.22 log units) away from the limit.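

In this assay compound 4 gives > 20000 nM, a limit and not a number. Methyl in place of 4-aminocyclohexyl on this nitrogen gives an at least 5.0-fold higher number from compound 3 to compound 4 (0.69 log units; beyond the scatter), so a group with no ring now joins 3-aminophenyl and 1-phenylethyl in giving no number, and among the four compounds only 4-aminocyclohexyl gives one at this place. The steps from compound 1 and from compound 2 to compound 4 cannot be read, with limits at both ends, and compound 4 shares its limit with compound 2: the limit of > 20000 nM in this assay, at which 2 of the 4 values shown sit.

On these data alone, whether the reading of compound 3 depends on the six-membered carbon ring, on the amine it carries, or on both stays open; compound 1 also carries an amine and still gives only a limit, and plain cyclohexyl or a 4-aminobutyl chain on the same nitrogen would separate these parts. As far as these compounds go, the full size of the loss with methyl also stays open, and the limit of compound 4 fixes only its minimum.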